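Compound 3: trimming the nitrogen substituent to methyl

A few compounds are considered here, and "the series" means these few. Any claim that something is new, unique, unknown or untested is made for them only; others in the source may bear on it.

Measured so far in a functional assay on MCF7 cells (Homo sapiens) for cytotoxicity; on this read-out higher numbers stand for weaker inhibition and lower numbers for stronger inhibition
Compound 1 `Cc1cc(Nc2nn(-c3ccc(F)cc3)c(=O)c3ccccc23)n[nH]1` gives 1600 nM
Compound 2 `Cc1cc(Nc2nn(Cc3cc(F)ccc3F)c(=O)c3ccccc23)n[nH]1` gives > 30000 nM as a limit

Compound 2 stands at the limit of > 30000 nM in this assay, at which 1 of the 2 values shown sits, and so has a limit and not a number. Compound 3 `Cc1cc(Nc2nn(C)c(=O)c3ccccc23)n[nH]1` differs from compound 2 by hydrogen in place of 2,5-difluorophenyl on a saturated chain carbon bound to an aromatic nitrogen and this amounts to hydrogen in place of 2,5-difluorophenyl on a saturated chain carbon bound to an aromatic nitrogen. Among the measured compounds shown here, the only measured step is an at least 18-fold higher number from compound 1 to compound 2 (1.27 log units; beyond the scatter) and it bears on this change only in part. It shows that swapping the group on the aromatic nitrogen can shift this assay strongly, but it gives no direction for methyl. A modest move towards lower numbers is expected, and compound 3 may also reach only the limit. The expected step is an at least 2.0-fold lower number from compound 2 to compound 3 (0.30 log units; that floor lies within the scatter) and it remains uncertain. Compound 3 is estimated at 15000 nM (expected range 4000 nM to 30000 nM).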

Compound 3, half-maximal inhibitory concentration: > 30000 nM
Compound 3 gave a limit, no number; the forecaster's own chance of this, stated with the estimate: 50%; middle value at least 2.0-fold (0.30 log units) away from the limit.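

In this assay compound 3 gives > 30000 nM, which is a limit and not a number. Among the compounds shown here, the change to methyl gives an at least 18-fold higher number from compound 1 to compound 3 (1.27 log units; beyond the scatter), so 4-fluorophenyl is now the only one of the three groups on the aromatic nitrogen with a readable number, and neither 2,5-difluorobenzyl nor methyl gives one. The step from compound 2 to compound 3 cannot be read, and the two compounds cannot be ranked, with both values sitting at the same limit: the limit of > 30000 nM in this assay, at which 2 of the 3 values shown sit.

From the compounds shown here alone, how far compound 2 and compound 3 lie past that limit remains open. Going by these compounds, it is also open whether the readable value of compound 1, 1600 nM, depends on the fluorine, and whether an unsubstituted phenyl or a pyridyl group on the aromatic nitrogen would also give a number.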